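Swapping the Outer Ring Once More

A few compounds are considered here, and "the series" means these few. Any claim that something is new, unique, unknown or untested is made for them only; others in the source may bear on it.

Going by the values given here, compound 2 `COC(=O)/C=C/c1cccc(N(Cc2ccc(-c3cccc(C(C)=O)c3)cc2)C(=O)C2CCCCC2)c1` holds the highest of the two numbers so far in an assay on isolated protein with Bile acid receptor (Homo sapiens) as the target (on this read-out lower numbers stand for an effect already at smaller amounts and higher numbers for an effect only at larger amounts of compound), where compound 2 gives 227 nM. Among the compounds with values here, compound 1 `COC(=O)/C=C/c1cccc(N(Cc2ccc(-c3ccc(F)c(Cl)c3)cc2)C(=O)C2CCCCC2)c1` gives 66 nM in this assay, and the single known step, a 3.4-fold higher number from compound 1 to compound 2 (0.54 log units; beyond the scatter), accompanied a change on the same outer ring. Compound 3 `COC(=O)/C=C/c1cccc(N(Cc2ccc(-c3cc(Cl)ccc3OC)cc2)C(=O)C2CCCCC2)c1` alters that ring again: 5-chloro-2-methoxyphenyl in place of 3-acetylphenyl on an aromatic carbon. Because compound 1 gives 66 nM with a chlorine-bearing ring, compound 3 is expected to recover part of the way, a 1.9-fold lower number from compound 2 to compound 3 (0.28 log units; within the scatter), landing at an estimated 120 nM with a range from 40 nM to 400 nM.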

Compound 3, half-maximal effective concentration: 233 nM
The estimate for compound 3 lay 1.9-fold (0.29 log units) below the measured number; low and high end bracket the measured number.
By their numbers in this assay, from the lowest: compound 1; then compounds 2 and 3 (each within the scatter of the next).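

In this assay there is a 1.0-fold higher number from compound 2 to compound 3 (0.01 log units; within the scatter) so two differently substituted outer rings read alike at this position. A chlorine on this ring does not by itself bring back the number of compound 1 since there is a 3.5-fold higher number from compound 1 to compound 3 (0.55 log units; beyond the scatter) and the 3-chloro-4-fluorophenyl ring remains the one that stands apart. Nothing measured here explains these results. As far as these compounds go, what remains open is which of the chlorine and methoxy groups of compound 3 matters, or how they act together. From the compounds shown here alone, how an outer ring carrying an amine or a carboxylic acid would read also remains open.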